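Replacing 4-Formylphenyl with 2-Nitrophenyl in Compound 3

The compounds below may be only part of what the source reports. "The series", "measured", "known", "first", "only" and "open" are said of these compounds alone.

Of the compounds shown here, three that share one core have been tested in a functional assay on SK-OV-3 cells (Homo sapiens) for inhibition, read by CCK-8 assay, with a stated time of 70 h; a lower number here means a stronger inhibitor, a higher number a weaker inhibitor. Compound 1 (`COc1ccc(COc2ccc(OCCOCCNC3CCCC3)cc2)cc1`) gives 15700 nM. Compound 3 (`O=Cc1ccc(COc2ccc(OCCOCCNC3CCCC3)cc2)cc1`) gives 45000 nM, the higher of the two exact numbers, which makes it the weaker inhibitor of this pair. Compound 2 (`O=C(O)c1ccccc1COc1ccc(OCCOCCNC2CCCC2)cc1`) reads > 100000 nM, which is a limit of the assay and not a number.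

Compound 4 (`O=[N+]([O-])c1ccccc1COc1ccc(OCCOCCNC2CCCC2)cc1`) has not yet been measured. It carries 2-nitrophenyl in place of the 4-formylphenyl of compound 3, on a saturated chain carbon bound to an oxygen on an aromatic ring: 2-nitrophenyl in place of 4-formylphenyl on a saturated chain carbon bound to an oxygen on an aromatic ring.

The measured steps all involve changes in this same part of the molecule. Formyl in place of methoxy gave a 2.9-fold higher number from compound 1 to compound 3 (0.46 log units; beyond the scatter). Replacing 4-methoxyphenyl with 2-carboxyphenyl gave an at least 6.3-fold higher number from compound 1 to compound 2 (0.80 log units; beyond the scatter), and replacing 2-carboxyphenyl with 4-formylphenyl gave an at least 2.2-fold lower number from compound 2 to compound 3 (0.34 log units; beyond the scatter). These last two steps rest on a limit, and all three are modest in size. Within the data shown here, no tested compound carries a nitro group, and the direction of the next step stays open. A modest step at most is therefore expected in this assay, possibly none beyond the scatter. The estimate amounts to a 1.1-fold lower number from compound 3 to compound 4 (0.05 log units; within the scatter), with no firm direction expected. For compound 4 the estimated value is 40000 nM, with an expected range from 14000 nM to 100000 nM.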

Compound 4, half-maximal inhibitory concentration: 5370 nM
The estimate for compound 4 lay 7.4-fold (0.87 log units) above the measured number; measured number outside the range, below it.
By their numbers in this assay, from the lowest: compound 4; then compound 1; then compound 3. At a limit, above all of these: compound 2.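

In this assay, both changes away from compound 1 had raised the number, so this position had shown only losses. The 2-nitrophenyl group reverses that, with a 2.9-fold lower number from compound 1 to compound 4 (0.47 log units; beyond the scatter) and an 8.4-fold lower number from compound 3 to compound 4 (0.92 log units; beyond the scatter), which makes compound 4 the strongest inhibitor of the four. The sharpest contrast comes from a change of one group on an aromatic carbon, nitro in place of carboxy, which gives an at least 18-fold lower number from compound 2 to compound 4 (1.27 log units; beyond the scatter); this shows that the group itself matters and not only where it sits, although compound 2 gives a limit and not a number: the limit of > 100000 nM in this assay, at which 1 of the 4 values shown sits.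

The compounds shown cannot separate the nitro group from its place on the ring, a question that a 4-nitrophenyl group or a 2-methoxyphenyl group at this position would address. They also leave open whether another group on the same ring, such as a nitrile or an amine, would give a number close to that of compound 4 or one far weaker.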